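A few compounds are considered here, and "the series" means these few. Any claim that something is new, unique, unknown or untested is made for them only; others in the source may bear on it.

Measured so far in a functional assay on HEK293 cells for activation of melanin-concentrating hormone receptor 1 (Rattus norvegicus), read by inositol phosphate accumulation; on this read-out lower numbers stand for an effect already at smaller amounts and higher numbers for an effect only at larger amounts of compound:

compound 1 `NC1CCN(c2ccc3cc(NC(=O)CCc4ccc(C(F)(F)F)cc4)ccc3n2)C1`: 200 nM
compound 2 `CNC(=O)NC1CCN(c2ccc3cc(NC(=O)CCc4ccc(C(F)(F)F)cc4)ccc3n2)C1`: 30 nM

For the measured compounds named here, compound 2 stands lowest of the two numbers so far; its nearest neighbour is compound 1, and the only measured step is a 6.7-fold lower number from compound 1 to compound 2 (0.82 log units; beyond the scatter), a change confined to the amine nitrogen on the five-membered ring.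

Compound 3 `O=C(CCc1ccc(C(F)(F)F)cc1)Nc1ccc2nc(N3CCC4(CCNC4)C3)ccc2c1` has not been measured. Its change from compound 2 is a group of 9 heavy atoms (7 carbon, 2 nitrogen; 2 five-membered non-aromatic rings with 1 hetero atom each) in place of a group of 10 heavy atoms (6 carbon, 3 nitrogen, 1 oxygen; one five-membered non-aromatic ring with 1 hetero atom), on an aromatic carbon

Going by the values given here, no measured step covers a change of this kind; the one step available, from compound 1 to compound 2, shows that the methylcarbamoyl on the amine nitrogen goes with the lower number, and compound 3 carries no such group, only a hydrogen-bond donor on the second five-membered ring. Among the compounds with values here, compound 3 therefore resembles compound 1 more than compound 2 in what is counted, and a step back toward the number of compound 1 is expected, that is a higher number than compound 2, a 5.0-fold higher number from compound 2 to compound 3 (0.70 log units; beyond the scatter), though the new second ring adds an uncertainty that no measured pair resolves. In this assay compound 3 is expected to give 150 nM, with a range of 40 nM to 600 nM.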

Compound 3, half-maximal effective concentration: 140 nM
Estimate against measurement, compound 3: 1.1-fold (0.03 log units) above; the measured number falls inside the stated range.
By their numbers in this assay, from the lowest: compound 2; then compounds 3 and 1 (each within the scatter of the next).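

In this assay, the group on the aromatic carbon next to the ring nitrogen can be exchanged for one with two five-membered non-aromatic rings, but the change from the 3-((methylcarbamoyl)amino)pyrrolidin-1-yl group gives a 4.7-fold higher number from compound 2 to compound 3 (0.67 log units; beyond the scatter), so the low number of compound 2 is lost. Compared with the smaller amine-bearing group of compound 1, the added ring shows no separable change: a 1.4-fold lower number from compound 1 to compound 3 (0.15 log units; within the scatter). For the compounds shown here, of the three groups at this position, only the one carrying methylcarbamoyl stands apart, and no measurement available here accounts for either step.

On these data alone, it remains open whether methylcarbamoyl on the ring amine of compound 3 would bring a drop like a 6.7-fold lower number from compound 1 to compound 2 (0.82 log units; beyond the scatter), which would show whether that step carries over to a different group at this position. Also open, as far as these compounds go, is how much of the low number of compound 2 depends on the urea itself, a question that an acetyl group in place of methylcarbamoyl, or a piperidine in place of the pyrrolidine, would address.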